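The source may hold more compounds than are shown below. What is called first, only, known or untested is meant among the compounds shown, and "the series" means these compounds.

Compound 1 `CCOC(=O)c1c(-c2ccc(F)cc2)oc2ccc(OCCN3C(=O)C(=O)c4ccccc43)cc12`: 128000 nM
Compound 2 `CCOC(=O)c1c(-c2ccc(F)cc2)oc2ccc(OCCN3C(=O)C(=O)c4cc(OC)ccc43)cc12`: 512000 nM

In an ADME assay on CHO cells (Cricetulus griseus) for cytotoxicity, read by MTT assay, with a stated time of 72 h (a lower number here means that less compound is tolerated, a higher number that more compound is tolerated), compound 2 holds the higher of the two numbers, at 512000 nM. Compound 3 `CCOC(=O)c1c(-c2ccc(F)cc2)oc2ccc(OCCN3C(=O)C(=O)c4cc(F)ccc43)cc12` is not yet measured and differs from it in one group: fluoro in place of methoxy on an aromatic carbon. Among the measured compounds shown here, the one measured step that bears on this is a 4.0-fold higher number from compound 1 to compound 2 (0.60 log units; beyond the scatter), where methoxy replaced hydrogen. For the measured compounds named here, no fluoro compound has been measured, but losing the methoxy may undo much of that modest rise, so a lower number is expected. The expected change is a 2.6-fold lower number from compound 2 to compound 3 (0.41 log units; beyond the scatter). Compound 3 is estimated at 200000 nM, with an expected range of 80000 nM to 500000 nM.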

Compound 3, half-maximal cytotoxic concentration: 64000 nM
Compound 3: the middle estimate sits 3.1-fold (0.49 log units) above what was measured; measured number below the stated range.
By their numbers in this assay, from the lowest: compounds 3 and 1 (each within the scatter of the next); then compound 2.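

In this assay, the swap from methoxy to fluoro gives an 8.0-fold lower number from compound 2 to compound 3 (0.90 log units; beyond the scatter) and so removes the earlier rise seen with methoxy. Fluoro in place of hydrogen gives a 2.0-fold lower number from compound 1 to compound 3 (0.30 log units; within the scatter) and so cannot be told apart from hydrogen here, which leaves methoxy as the only one of these three groups that stands apart. Nothing measured here accounts for this difference. On these data alone, whether a longer chain such as ethoxy, or an amine, would behave like methoxy remains open. So does whether methoxy would have the same effect on another carbon of this ring.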